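Removing a Methoxy Group from Compound 2

This account rests on a few compounds, and the source may have more. Where it says the series, first, only, none or still open, it means among the compounds named here.

Compound 1: `COc1cc(O)c(C(=O)/C=C/c2ccc(F)cc2)c(OC)c1`, 13200 nM
Compound 2: `COc1cccc(/C=C/C(=O)c2c(OC)cc(OC)cc2OC)c1`, 3100 nM

Of the compounds shown here, two have been measured in a functional assay on PC-3 cells (Homo sapiens) for cytotoxicity, with a stated time of 48 h; on this read-out lower numbers stand for stronger inhibition and higher numbers for weaker inhibition. Compound 2 gives the lower of the two numbers, and compound 1 stands a clear step higher, beyond the usual scatter of repeated runs. Among the measured compounds shown here, no pair of the measured compounds differs in only one place, so no single measured step is available to guide the next comparison directly.

Compound 3 is `COc1cc(OC)c(C(=O)/C=C/c2ccccc2)c(OC)c1` and has not yet been measured. It differs from compound 2 by hydrogen in place of methoxy on an aromatic carbon. For the measured compounds named here, with no measured step of this kind to lean on, the expectation is a small step toward a weaker result, one that may still fall within the scatter. The expected step is a 1.6-fold higher number from compound 2 to compound 3 (0.21 log units; within the scatter). Compound 3 is estimated to give 5000 nM, with a range from 1500 nM to 16000 nM.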

Compound 3, half-maximal inhibitory concentration: 5100 nM
Compound 3: the middle estimate sits 1.0-fold (0.01 log units) below what was measured, and the stated range covers the measured number.
By their numbers in this assay, from the lowest: compounds 2 and 3 (each within the scatter of the next); then compound 1.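

Among the compounds shown here, this is the first comparison in the set that differs in one place: in this assay, hydrogen in place of methoxy on an aromatic carbon, meta to a large group, gives a 1.6-fold higher number from compound 2 to compound 3 (0.22 log units; within the scatter). Compound 2 and compound 3 therefore cannot be told apart, which shows that the read-out stays at the level of compound 2 without a methoxy group at this position. Nothing at hand gives a reason for this result.

From the compounds shown here alone, it remains open whether another group at this position, such as an amine, a carboxylic acid or a longer alkoxy chain, would separate from these two compounds. Going by these compounds, it is also open whether the same replacement would give a similar result on a different core, since compound 1 differs from both in more than one place.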